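Trading an Amine Arm for an Amide on the Macrocycle

The source may hold more compounds than are shown below. What is called first, only, known or untested is meant among the compounds shown, and "the series" means these compounds.

Measured compounds:
compound 1 `CC(C)=CCC[C@]1(C)/C=C/[C@@H](OC(=O)C=C(C)C)[C@](C)(O)/C=C/C(=O)/C(CN(C(C)C)C(C)C)=C\C1`: 740 nM
compound 2 `CC(C)=CCC[C@]1(C)/C=C/[C@@H](OC(=O)C=C(C)C)[C@](C)(O)/C=C/C(=O)/C(COC(=O)c2ccc([N+](=O)[O-])cc2)=C\C1`: 830 nM

In a functional assay on HL-60 cells (Homo sapiens) for antiproliferative activity, read by MTT assay, with a stated time of 48 h (a lower number here means a stronger inhibitor, a higher number a weaker inhibitor), compound 1 gives 740 nM, the lowest of the two numbers, and compound 2 is nearest with 830 nM. Within the data shown here, the single measured step, a 1.1-fold higher number from compound 1 to compound 2 (0.05 log units; within the scatter), lies within the scatter, so the two numbers cannot be told apart.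

Compound 3 `CCN(CC)C(=O)/C1=C/C[C@](C)(CCC=C(C)C)/C=C/[C@@H](OC(=O)C=C(C)C)[C@](C)(O)/C=C/C1=O` differs from compound 1 by diethylcarbamoyl in place of (diisopropylamino)methyl on a double-bonded ring carbon. Among the measured compounds shown here, the only measured step bears on this comparison loosely: it also changed the group attached around the double-bonded ring carbon of the shared core, and it moved the number by no more than the scatter. Nothing measured shows that reshaping this arm shifts the read-out in either direction. For the measured compounds named here, the expectation is therefore a step of a 1.2-fold higher number from compound 1 to compound 3 (0.09 log units; within the scatter), with no change beyond the scatter expected, though the uncertainty is wide because only one step exists. Compound 3 is estimated at 900 nM, within a range from 300 nM to 2700 nM.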

Compound 3, half-maximal inhibitory concentration: 9080 nM
The estimate for compound 3 lay 10-fold (1.00 log units) below the measured number, outside the stated range (above it).
By their numbers in this assay, from the lowest: compounds 1 and 2 (each within the scatter of the next); then compound 3.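

In this assay, replacing (diisopropylamino)methyl with diethylcarbamoyl on the double-bonded ring carbon gives a 12-fold higher number from compound 1 to compound 3 (1.09 log units; beyond the scatter), which shows that the read-out can respond strongly to the group at this position. Among these compounds, the earlier change at the same place, a 1.1-fold higher number from compound 1 to compound 2 (0.05 log units; within the scatter), therefore shows only that those two groups cannot be told apart, not that this position accepts any group equally well. The two groups in the new step have the same counts of hydrogen-bond donors and acceptors and neither carries a net charge, so those counts do not separate them, and no measurement at hand gives a cause for the step.

This step changes two things at once: the carbonyl now stands directly on the ring carbon, and diethyl replaces diisopropyl on the nitrogen. How a (diethylamino)methyl or a diisopropylcarbamoyl group would read at this position stays open, and with it the question of which of those two changes accounts for the step.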